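This account rests on a few compounds, and the source may have more. Where it says the series, first, only, none or still open, it means among the compounds named here.

Measured so far in a functional assay on HT-29 cells (Homo sapiens) for inhibition, read by MTT assay, with a stated time of 120 h; on this read-out lower numbers stand for stronger inhibition and higher numbers for weaker inhibition:
- compound 1 `CC1CN(C(=O)c2ccc(-c3ccc(NC(=O)Nc4ccc(Cl)c(C(F)(F)F)c4)cc3)cc2)CC(C)O1` gives 2050 nM
- compound 2 `CNC(=O)CCc1ccc(NC(=O)Nc2ccc(Cl)c(C(F)(F)F)c2)cc1` gives 20600 nM
- compound 3 `CC(NC(=O)/C=C/c1ccc(NC(=O)Nc2cc(C(F)(F)F)ccc2Cl)cc1)c1ccccc1` gives 4190 nM

Compound 1 has the lowest number of the three. Compound 3 is its nearest neighbour, and that gap already lies beyond the scatter; the gap to compound 2 is wider still.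

Compound 4 `CC(NC(=O)c1ccc(-c2ccc(NC(=O)Nc3ccc(Cl)c(C(F)(F)F)c3)cc2)cc1)c1ccccc1` is the next step from compound 1: (1-phenylethyl)amino in place of 2,6-dimethylmorpholin-4-yl on a carbonyl carbon. Going by the values given here, no step between two measured compounds reproduces this change, so there is no measured precedent to scale it against. What the numbers do show is that compound 3, which carries the same (1-phenylethyl)amino group on a carbonyl carbon within an otherwise different molecule, sits at 4190 nM, the smallest gap to compound 1 in this set. The expectation is therefore a step of modest size toward a somewhat higher number, not far beyond the scatter: a 1.4-fold higher number from compound 1 to compound 4 (0.14 log units; within the scatter). For compound 4 the estimate in this assay is 2800 nM, with a range from 900 nM to 9000 nM.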

Compound 4, half-maximal inhibitory concentration: 5960 nM
The estimate for compound 4 lay 2.1-fold (0.33 log units) below the measured number; measured number inside the range.
By their numbers in this assay, from the lowest: compound 1; then compounds 3 and 4 (each within the scatter of the next); then compound 2.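

Going by these compounds alone, at the carbonyl carbon of the core of compound 1, the change from 2,6-dimethylmorpholin-4-yl to (1-phenylethyl)amino provides the first one-place comparison. In this assay it gives a 2.9-fold higher number from compound 1 to compound 4 (0.46 log units; beyond the scatter) and so weakens inhibition by a modest step, while the replacement of a non-aromatic ring without a hydrogen-bond donor by an aromatic ring with the amide hydrogen still leaves a measurable value. Nothing at hand accounts for the size of this step.

Within the data shown here, the single step cannot separate the contribution of the aromatic ring from that of the amide hydrogen. From the compounds shown here alone, how a piperidine, a dimethylamino group or a benzylamino group would read on the same carbonyl carbon remains open, as does the effect of a carboxylic acid elsewhere on the core.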